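Adding a Chloro Group to the Unsubstituted Ring

This account rests on a few compounds, and the source may have more. Where it says the series, first, only, none or still open, it means among the compounds named here.

Measured compounds:
Compound 1 `CCC(=O)N1N=C(c2ccc(Cl)cc2)CC1c1ccc(Cl)cc1`: 10000 nM
Compound 2 `CCC(=O)N1N=C(c2ccc(F)cc2)CC1c1ccccc1`: 200 nM

In an assay on isolated protein for inhibition of Amine oxidase [flavin-containing] B (Bos taurus) (on this read-out lower numbers stand for stronger inhibition and higher numbers for weaker inhibition), compound 2 gives 200 nM, the lower of the two numbers, with compound 1 standing a long way higher. Compound 3 `CCC(=O)N1N=C(c2ccc(F)cc2)CC1c1ccc(Cl)cc1` has not been measured. It differs from compound 2 by chloro in place of hydrogen on an aromatic carbon. For the measured compounds named here, no comparable step between measured compounds is available, so the size of this step is uncertain. Compound 3 is expected to be weaker than compound 2 because compound 1, which carries chloro on both rings, gives 10000 nM. The expected step of a 7.5-fold higher number from compound 2 to compound 3 (0.88 log units; beyond the scatter) is therefore a loss of potency beyond the scatter. Compound 3 is estimated at 1500 nM, within a range from 300 nM to 8000 nM.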

Compound 3, half-maximal inhibitory concentration: 6310 nM
Beside the measured number, compound 3's estimate is 4.2-fold (0.62 log units) below it; measured number inside the range.
By their numbers in this assay, from the lowest: compound 2; then compounds 3 and 1 (each within the scatter of the next).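

In this assay, the change from phenyl to 4-chlorophenyl on this ring costs a large amount of potency (a 32-fold higher number from compound 2 to compound 3 (1.50 log units; beyond the scatter)). Fluoro in place of chloro on the other ring, by contrast, leaves the number within the scatter (a 1.6-fold lower number from compound 1 to compound 3 (0.20 log units; within the scatter)), so among these compounds the weak inhibition tracks with the chloro at this position. No measurement here explains this loss.

As far as these compounds go, whether a methyl or a methoxy group at this same place would also weaken inhibition stays open. So does whether the loss is specific to chloro.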